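The compounds below may be only part of what the source reports. "The series", "measured", "known", "first", "only" and "open" are said of these compounds alone.

Measured so far in a functional assay on T-24 cells (Homo sapiens) for cytotoxicity, read by colorimetric assay and MTT assay; on this read-out higher numbers stand for weaker inhibition and lower numbers for stronger inhibition:
- compound 1 `COc1cccc2cc(-c3ccccc3)c(O)nc12` gives 10000 nM
- compound 2 `COc1ccc2cc(-c3ccccc3)c(O)nc2c1` gives 10000 nM

Not yet measured: compound 3 `COc1cc(OC)c2cc(-c3ccccc3)c(O)nc2c1`

Compound 2 stands level with compound 1, with no difference beyond the scatter. Going to compound 3 adds one group to compound 2, methoxy in place of hydrogen on an aromatic carbon is the whole change. Within the data shown here, no step between measured compounds shows what such a change does, so no step beyond the scatter is expected in this assay. The estimated change, a 1.3-fold lower number from compound 2 to compound 3 (0.10 log units; within the scatter), stays within the scatter. For compound 3 the estimated value is 8000 nM, with an expected range from 2500 nM to 20000 nM as its bounds.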

Compound 3, half-maximal inhibitory concentration: 10000 nM
Compound 3: middle estimate off by 1.3-fold (0.10 log units), on the low side; the measured number falls inside the stated range.
By their numbers in this assay, from the lowest: compounds 1, 2 and 3 (each within the scatter of the next).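

In this assay, among these compounds, methoxy in place of hydrogen on an aromatic carbon, ortho to a fused ring and meta to a methoxy group, gives no change at the digits printed from compound 2 to compound 3 (within the scatter) as the first readable step. At this position, a second methoxy group therefore gives no step beyond the scatter. No supporting measurement offers an explanation for this result.

Still open, from the compounds shown here alone, is whether an amine, a carboxylic acid or a longer chain at this position would give a step beyond the scatter. The compounds shown also leave open how a hydroxy group there would read.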